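The compounds below may be only part of what the source reports. "The series", "measured", "known", "first", "only" and "open" are said of these compounds alone.

Working notes on a series of dichloropurines carrying a benzyl group with a chloromethyl substituent, assessed in a functional assay on TK-10 cells (Homo sapiens) for cytotoxicity, read by sulforhodamine B assay, with a stated time of 48 h; on this read-out lower numbers stand for stronger inhibition of growth and higher numbers for weaker inhibition of growth.

Compound 1 `ClCc1cccc(Cn2cnc3c(Cl)nc(Cl)nc32)c1` gives 1730 nM in this assay. Compound 2 `ClCc1cccc(Cn2cnc3nc(Cl)nc(Cl)c32)c1` gives 16600 nM in this assay. Compound 3 `ClCc1ccccc1Cn1cnc2nc(Cl)nc(Cl)c21` gives 19500 nM in this assay. On these three numbers compound 2 stands second highest; its nearest neighbour is compound 3, whose number lies within the scatter of the number for compound 2, so no order between those two is claimed, while compound 1 is the furthest off, with a number beyond the scatter below that of compound 2.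

Compound 4 `ClCc1cccc(Cn2cnc3ncnc(Cl)c32)c1` has not been measured in this assay. It differs from compound 2 in one place: hydrogen in place of chloro on an aromatic carbon. Going by the values given here, no measured pair shows this change, so its effect can only be guessed. With one chloro fewer on the shared core, a modest weakening of growth inhibition is expected, i.e. a step of a 2.1-fold higher number from compound 2 to compound 4 (0.32 log units; beyond the scatter) in this assay that may reach beyond the scatter but is not expected to be large. Compound 4 is therefore estimated at 35000 nM in this assay, with a range from 10000 nM to 120000 nM.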

Compound 4, concentration for 50% growth inhibition: 1770 nM
For compound 4 the middle estimate is 20-fold (1.30 log units) above the measured one, and the stated range ends above it.
By their numbers in this assay, from the lowest: compounds 1 and 4 (each within the scatter of the next); then compounds 2 and 3 (each within the scatter of the next).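

In this assay, going by these compounds alone, hydrogen in place of chloro on the aromatic carbon between two ring nitrogen atoms gives a 9.4-fold lower number from compound 2 to compound 4 (0.97 log units; beyond the scatter), the first change at a single place that can be read. Growth inhibition therefore does not depend on this chloro here: it strengthens when the chloro leaves, and compound 4 keeps only the chloro group meta to this position on the shared core. Nothing measured on these compounds accounts for the size or direction of this step.

The compounds shown leave open how an amine, a methoxy group or a thiol on this same carbon would compare with hydrogen and chloro, so a single replacement defines what this position tolerates only in part. They also leave open whether the same step would appear with the chloromethyl benzyl group of compound 3, and what hydrogen in place of the remaining chloro of compound 4 would do.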